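A few compounds are considered here, and "the series" means these few. Any claim that something is new, unique, unknown or untested is made for them only; others in the source may bear on it.

Of the compounds shown here, three sharing one core have been measured in a functional assay on MCF7 cells (Homo sapiens) for cytotoxicity, read by MTT assay, with a stated time of 72 h; on this read-out higher numbers stand for weaker inhibition of growth and lower numbers for stronger inhibition of growth. Compound 1 `C=CCOC(=O)Nc1ccc([Se]C#N)cc1` gives 43100 nM. Compound 2 `CCOC(=O)Nc1ccc([Se]C#N)cc1` gives 36700 nM, and compound 3 `N#C[Se]c1ccc(NC(=O)Oc2ccccc2)cc1` gives 35900 nM. The steps between them are all small: a 1.2-fold lower number from compound 1 to compound 2 (0.07 log units; within the scatter), a 1.2-fold lower number from compound 1 to compound 3 (0.08 log units; within the scatter) and a 1.0-fold lower number from compound 2 to compound 3 (0.01 log units; within the scatter). Compound 3 thus carries the lowest of the three numbers, but its nearest neighbour, compound 2, and the furthest, compound 1, both sit within the scatter of it, so no order among the three can be claimed.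

Compound 4 `Cc1ccc(OC(=O)Nc2ccc([Se]C#N)cc2)cc1` differs from compound 3 by methyl in place of hydrogen on an aromatic carbon. For the measured compounds named here, none of the measured steps touches this part of the molecule; all three exchange one group for another elsewhere in the structure, and each stayed within the scatter. Nothing in these data points to a change in this assay beyond the scatter in either direction. The step expected in this assay is a 1.1-fold lower number from compound 3 to compound 4 (0.02 log units; within the scatter), that is, none beyond the scatter. Compound 4 is estimated at 34000 nM, with a range of 17000 nM to 68000 nM.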

Compound 4, concentration for total growth inhibition: 39900 nM
The estimate for compound 4 lay 1.2-fold (0.07 log units) below the measured number; measured number inside the range.
By their numbers in this assay, from the lowest: compounds 3, 2, 4 and 1 (each within the scatter of the next).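

In this assay, methyl in place of hydrogen on an aromatic carbon, para to a large group, gives a 1.1-fold higher number from compound 3 to compound 4 (0.05 log units; within the scatter). The earlier steps shown here exchanged only the whole group on the oxygen next to a carbonyl group, whereas this one adds a single carbon to the six-membered aromatic ring of compound 3, and it too stays within the scatter. No measurement available here accounts for the size of this step.

From the compounds shown here alone, whether a carboxylic acid or an amine on this aromatic carbon would shift the number beyond the scatter remains open. Also open, going by these compounds, is whether any exchange in the shared core, rather than in the group on the oxygen, would separate compounds in this assay at all.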